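Replacing a dimethoxyphenyl with an isopropylphenyl on the core

The source may hold more compounds than are shown below. What is called first, only, known or untested is meant among the compounds shown, and "the series" means these compounds.

Measured so far:
Compound 1 `CCCc1ccc(C2CC(c3ccc(O)cc3)=NN2C(=O)c2cccnc2)cc1`: 41600 nM
Compound 2 `COc1ccc(C2CC(c3ccc(O)cc3)=NN2C(=O)c2cccnc2)cc1OC`: 53600 nM
Compound 3 `O=C(c1cccnc1)N1N=C(c2ccc(O)cc2)CC1c1ccc(OCc2ccccc2)cc1`: 11400 nM

These three compounds share one core and were tested in an ADME assay on HepG2 cells (Homo sapiens) for cytotoxicity, read by MTT assay, with a stated time of 7 days; a higher number here means a weaker inhibitor, a lower number a stronger inhibitor. Compound 2 and compound 1 give numbers that lie within the scatter of each other, as the step of a 1.3-fold higher number from compound 1 to compound 2 (0.11 log units; within the scatter) shows. Compound 3 gives a clearly lower number than compound 2, but these two compounds differ in more than one place, so only their values can be compared.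

Compound 4 `CC(C)c1ccc(C2CC(c3ccc(O)cc3)=NN2C(=O)c2cccnc2)cc1` has not yet been measured. It differs from compound 2 in one place: 4-isopropylphenyl in place of 3,4-dimethoxyphenyl on a saturated ring carbon

The step that bears most on this change is a 1.3-fold higher number from compound 1 to compound 2 (0.11 log units; within the scatter), since a 4-propylphenyl and a 4-isopropylphenyl are close in build, and that step stayed within the scatter. The step of a 3.6-fold lower number from compound 1 to compound 3 (0.56 log units; beyond the scatter) concerns a different place on the core and is less informative here. Compound 4 is therefore expected to give a number close to compound 1, which means a step of a 1.2-fold lower number from compound 2 to compound 4 (0.09 log units; within the scatter), not beyond the scatter. The estimate for compound 4 is 44000 nM, with a range from 20000 nM to 95000 nM.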

Compound 4, half-maximal inhibitory concentration: 38700 nM
Compound 4: the middle estimate sits 1.1-fold (0.06 log units) above what was measured; measured number inside the range.
By their numbers in this assay, from the lowest: compound 3; then compounds 4, 1 and 2 (each within the scatter of the next).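

In this assay, the group on the saturated ring carbon can change from 3,4-dimethoxyphenyl, with 2 hydrogen-bond acceptors, to 4-isopropylphenyl, with 0, and the result is a 1.4-fold lower number from compound 2 to compound 4 (0.14 log units; within the scatter); this change of atoms and acceptor count therefore leaves no mark beyond the scatter. The shape of the small chain does not separate the compounds either: exchanging propyl for isopropyl on the aromatic carbon gives a 1.1-fold lower number from compound 1 to compound 4 (0.03 log units; within the scatter), so the branched and straight chains cannot be told apart here. Benzyloxy still stands apart, with a 3.4-fold higher number from compound 3 to compound 4 (0.53 log units; beyond the scatter), a modest step that now shows compound 3 apart from both the propyl and isopropyl compounds on the same aromatic carbon.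

No measured evidence accounts for why these groups give the numbers they do. From the compounds shown here alone, it remains open whether an amine, a carboxylic acid or a chain longer than propyl on that aromatic carbon would stay with compounds 1 and 4 or shift the number as benzyloxy does.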